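The source may hold more compounds than are shown below. What is called first, only, known or untested is meant among the compounds shown, and "the series" means these compounds.

Three compounds with a shared core have so far been taken into an ADME assay on microsomes from liver (Mus musculus) for metabolic stability, with a stated time of 10 min (a higher number here means that more of the compound is left, a lower number that less of the compound is left), for comparison. For compound 1 `CCC[C@]1(C(=O)N2CC[C@](c3ccc(C(F)(C(F)(F)F)C(F)(F)F)cc3)(S(=O)(=O)c3ccc(F)cc3)C2)CC[C@H](C(=O)O)CC1` the record reads "not determined" (no result reported) and offers nothing to compare. Compound 3 `O=C(O)C1CCC(O)(C(=O)N2CC[C@](c3ccc(C(F)(C(F)(F)F)C(F)(F)F)cc3)(S(=O)(=O)c3ccc(F)cc3)C2)CC1` gives 99%; 98% (2 entries) in this assay on repeat readings, and the several entries of compound 3 in this assay, 99%; 98% (2 entries) shows how closely they agree. Compound 2 `CO[C@]1(C(=O)N2CC[C@](c3ccc(C(F)(C(F)(F)F)C(F)(F)F)cc3)(S(=O)(=O)c3ccc(F)cc3)C2)CC[C@H](C(=O)O)CC1` stands at 95% on a single reading, within the usual scatter of compound 3, so the two cannot be told apart.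

Compound 4 `C[C@]1(C(=O)N2CC[C@](c3ccc(C(F)(C(F)(F)F)C(F)(F)F)cc3)(S(=O)(=O)c3ccc(F)cc3)C2)CC[C@@H](C(=O)O)CC1` has not yet been measured. It differs from compound 2 at one place, 4-carboxy-1-methylcyclohexyl in place of 4-carboxy-1-methoxycyclohexyl on a carbonyl carbon with 4-carboxy-1-methylcyclohexyl in place of 4-carboxy-1-methoxycyclohexyl on a carbonyl carbon whose other neighbours are an amide-type nitrogen in a ring. Within the data shown here, no measured pair isolates a change of this kind, so the expectation can rest only on the level of the neighbouring compounds. With compound 2 at 95% and compound 3 at 99%; 98% (2 entries) very little is lost from either. The step of a number 3 percentage points lower from compound 2 to compound 4 (within the scatter) is therefore expected to be a slight drop that stays inside the usual scatter. In this assay the estimate for compound 4 is 92% with 80% to 100% as the expected range.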

Compound 4, percent of the compound remaining: 100%
Compound 4: the middle estimate sits 8 percentage points below what was measured, within the range that was stated.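

In this assay, 4-carboxy-1-methylcyclohexyl in place of 4-carboxy-1-methoxycyclohexyl on a carbonyl carbon gives a number 5 percentage points higher from compound 2 to compound 4 (within the scatter) and so leaves the two compounds indistinguishable. Among these compounds, this is the first measured pair to isolate a change at this place, and it shows that the methoxy group can give way to a methyl group without a readable change in how much compound is left at the stated time. Both compounds sit near the top of the scale, where little room remains to show a step, and repeat readings in the same assay can agree closely, as another compound with the shared core shows: the several entries of compound 3 in this assay, 99%; 98% (2 entries).

The compounds shown leave open whether any group at this place would bring the read-out down, since a single readable step within the scatter sets no trend, and an amine or an ethoxy group there could still behave differently. They also leave open whether compound 2 and compound 4 could be told apart under conditions that leave less of either compound behind.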